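Swapping the aryl group on an amine in a lactone series

This account rests on a few compounds, and the source may have more. Where it says the series, first, only, none or still open, it means among the compounds named here.

Of the compounds shown here, three from one set have been tested in a functional assay on MCF7 cells (Homo sapiens) for cytotoxicity, read by sulforhodamine B assay; on this read-out lower numbers stand for stronger inhibition and higher numbers for weaker inhibition. Compound 1 `C=C1[C@@H](C/C=C2/C(=O)OC[C@H]2OC(C)=O)[C@]2(C)CC[C@@H](OC(C)=O)[C@@](C)(CO[Si](C)(C)C(C)(C)C)[C@H]2C[C@@H]1O` gives 6960 nM. Compound 3 `C=C1[C@@H](OC(C)=O)C[C@@H]2[C@](C)(CO[Si](C)(C)C(C)(C)C)[C@H](OC(C)=O)CC[C@@]2(C)[C@@H]1C[C@@H](Nc1cccc(F)c1)C1=CCOC1=O` gives 3820 nM. Compound 2 `C=C1[C@@H](OC(C)=O)C[C@@H]2[C@](C)(COC=O)[C@H](OC(C)=O)CC[C@@]2(C)[C@@H]1C[C@@H](Nc1ccccc1C(=O)O)C1=CCOC1=O` gives 30800 nM, the highest of the three numbers; its gap to compound 1 and its larger gap to compound 3 both lie beyond the usual scatter, so compound 2 is the weakest of the measured three in this assay.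

The step considered here leads from compound 2 to compound 4 `C=C1[C@@H](OC(C)=O)C[C@@H]2[C@](C)(COC=O)[C@H](OC(C)=O)CC[C@@]2(C)[C@@H]1C[C@@H](Nc1cccc2ccccc12)C1=CCOC1=O`, which has not yet been measured. The two structures share the same core and differ at one site: naphthalen-1-yl in place of 2-carboxyphenyl on an amine nitrogen. Among the measured compounds shown here, no pair of measured compounds differs by exactly this change, so no measured step can be borrowed. For the measured compounds named here, what can be said is that the only measured compound without the 2-carboxyphenyl group, compound 3, gives 3820 nM, a lower number than compound 2, although compound 3 also differs elsewhere.

On that basis compound 4 is expected to give 10000 nM, with a plausible range from 3000 nM to 30000 nM. The expected step of a 3.1-fold lower number from compound 2 to compound 4 (0.49 log units; beyond the scatter) would be a modest move toward stronger inhibition, though the uncertainty is wide enough that no change beyond the scatter would not be surprising.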

Compound 4, half-maximal inhibitory concentration: 9750 nM
Estimate against measurement, compound 4: 1.0-fold (0.01 log units) above; the range from low to high includes it.
By their numbers in this assay, from the lowest: compounds 3, 1 and 4 (each within the scatter of the next, the first and the last beyond it); then compound 2.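

In this assay, among the compounds shown here, naphthalen-1-yl in place of 2-carboxyphenyl on the amine nitrogen gives a 3.2-fold lower number from compound 2 to compound 4 (0.50 log units; beyond the scatter), the first measured step in this set that changes one site while the rest of the structure stays the same. It shows that the aryl group on this nitrogen can, by itself, shift the number beyond the scatter, and that a carboxylic acid on the aryl group is not needed for activity at this level. No measurement shown here accounts for the size or direction of this step.

The swap changes several things at once: one aromatic ring becomes two, and the carboxylic acid with its hydrogen-bond donor and acceptor is lost, so the step cannot show which of these changes matters. A plain phenyl group on the same nitrogen would separate the loss of the carboxylic acid from the gain of the second ring, and a methyl ester in place of the acid would test whether the acid's free hydrogen matters.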